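The source may report more compounds than this note shows. Statements on the series, on what has been measured and on what is new or still open speak of the compounds shown alone.

Of the compounds shown here, three built on one shared core have been measured in a functional assay on MCF7 cells (Homo sapiens) for inhibition, read by sulforhodamine B assay, with a stated time of 48 h; a higher number here means a weaker inhibitor of growth, a lower number a stronger inhibitor of growth. Compound 1 `N=C(N)c1ccc(-c2ccc(-c3ccc(F)cc3)s2)cc1` gives 323 nM in this assay. Compound 2 `N=C(N)c1ccc(-c2ccc(-c3ccc(Cl)cc3)s2)cc1F` gives 168 nM in this assay, and compound 3 `COc1cc(OC)cc(-c2ccc(-c3ccc(C(=N)N)c(F)c3)s2)c1` gives 194 nM in this assay. Compound 2 has the lowest of the three numbers, yet compound 3 sits within the scatter of it and so does compound 1, so the three cannot be ranked against one another on these numbers.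

Compound 4 `COc1ccc(-c2ccc(-c3ccc(C(=N)N)c(F)c3)s2)cc1` has not yet been measured in this assay. It differs from compound 2 in one place: methoxy in place of chloro on an aromatic carbon. Within the data shown here, no pair of measured compounds differs in only this one place, so there is no measured step to lean on. What can be said is that compound 3, which carries methoxy groups rather than a chloro, gives 194 nM, while compound 2 gives 168 nM, and that difference lies within the scatter. On this basis the expected step in this assay is a 1.5-fold higher number from compound 2 to compound 4 (0.17 log units; within the scatter), with no clear direction beyond the scatter. Compound 4 is estimated at 250 nM in this assay, within a range from 100 nM to 600 nM.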

Compound 4, concentration for 50% growth inhibition: 2080 nM
Compound 4: the middle estimate sits 8.3-fold (0.92 log units) below what was measured; measured number outside the range, above it.
By their numbers in this assay, from the lowest: compounds 2, 3 and 1 (each within the scatter of the next); then compound 4.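

In this assay, the group on this aromatic carbon, para to a large group, clearly matters: methoxy in place of chloro gives a 12-fold higher number from compound 2 to compound 4 (1.09 log units; beyond the scatter) and stands as the only one-place change measured among these compounds. The swap itself is small, with one chlorine leaving and one carbon plus one oxygen entering, and methoxy counts one hydrogen-bond acceptor where chloro counts none, so a change of very few atoms can go with a large loss of growth inhibition in this series. The result gives the size and direction of the step, but no measurement shown here explains it.

As far as these compounds go, it remains open whether this loss is particular to methoxy or would follow from other replacements for chloro, such as a hydroxyl, an amine, a methyl or a bromo on the same carbon. Also open, from the compounds shown here alone, is whether the same swap produces a step of similar size in a compound lacking the fluoro that compound 2 and compound 4 both carry.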